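Removing one methoxy from compound 1

The source may hold more compounds than are shown below. What is called first, only, known or untested is meant among the compounds shown, and "the series" means these compounds.

Measured compounds:
- compound 1 `COc1cc(/C=C/C(=O)Nc2cc3c(Nc4ccc(F)c(Cl)c4)ncnc3cc2O[C@H]2CCOC2)cc(OC)c1OC`: 24500 nM
- compound 2 `COc1ccc(/C=C/C(=O)Nc2cc3c(Nc4ccc(F)c(Cl)c4)ncnc3cc2OC)c(OC)c1`: "not determined" (no result reported)
- compound 3 `COc1cc2ncnc(Nc3ccc(F)c(Cl)c3)c2cc1NC(=O)/C=C/c1cc(OC)c(OC)c(OC)c1`: "not determined" (no result reported)

Among the compounds with values here, in a functional assay on HeLa cells (Homo sapiens) for cytotoxicity, read by MTT assay, with a stated time of 72 h (on this read-out higher numbers stand for weaker inhibition and lower numbers for stronger inhibition), compound 1 gives 24500 nM, the only number available, as neither compound 2 nor compound 3 has a reported result. It therefore cannot be ranked against any other compound. Compound 4 `COc1cc(/C=C/C(=O)Nc2cc3c(Nc4ccc(F)c(Cl)c4)ncnc3cc2O[C@H]2CCOC2)cc(OC)c1` has not been measured. It turns the 3,4,5-trimethoxyphenyl of compound 1 into 3,5-dimethoxyphenyl, with hydrogen in place of methoxy on an aromatic carbon. Within the data shown here, no measured pair shows what such a change does, so no shift beyond the scatter is expected in this assay. The expected size of the change is a 1.2-fold lower number from compound 1 to compound 4 (0.09 log units; within the scatter). For compound 4 the estimated value is 20000 nM, with an expected range of 7000 nM to 50000 nM.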

Compound 4, half-maximal inhibitory concentration: 34300 nM
For compound 4 the middle estimate is 1.7-fold (0.23 log units) below the measured one, within the range that was stated.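

In this assay, within the data shown here, the change from 3,4,5-trimethoxyphenyl to 3,5-dimethoxyphenyl gives a 1.4-fold higher number from compound 1 to compound 4 (0.15 log units; within the scatter) and is the first step that can be read at this position. It shows that hydrogen can take the place of this methoxy without a shift beyond the scatter. Nothing available explains this result. As far as these compounds go, whether an amine, a hydroxyl or a longer alkoxy chain on this aromatic carbon would behave in the same way remains open. So does the effect of replacing either of the two remaining methoxy groups.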